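From Ethoxy to Dimethylamino: Expecting a Small Step

The compounds below may be only part of what the source reports. "The series", "measured", "known", "first", "only" and "open" are said of these compounds alone.

Compound 3 `CCOc1ccc(/C=N/NC(=O)c2cnccn2)cc1` was tested in an ADME assay on J774 cells (Mus musculus) for cytotoxicity, read by MTT assay, with a stated time of 48 h, tested at 100 ug/mL (on this read-out lower numbers stand for a stronger effect and higher numbers for a weaker effect at the one concentration tested), and gives 98%. Among the three measured compounds this is the second highest number. Its nearest neighbour is compound 2 `O=C(N/N=C/c1ccc(Br)cc1)c1cnccn1`, which gives 100%, a number within the scatter of compound 3. Furthest away is compound 1 `O=C(N/N=C/c1ccccc1)c1cnccn1`, which gives 75%, beyond the scatter from compound 3. Two steps place a group on an aromatic carbon of compound 1, each a modest rise: a number 25 percentage points higher from compound 1 to compound 2 (beyond the scatter) and a number 23 percentage points higher from compound 1 to compound 3 (beyond the scatter).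

Compound 4 `CN(C)c1ccc(/C=N/NC(=O)c2cnccn2)cc1` has not yet been measured. It differs from compound 3 in one place: dimethylamino in place of ethoxy on an aromatic carbon. Among the measured compounds shown here, the step that bears most directly on this change is the one that also exchanges one group for another on that same aromatic carbon, and that step stayed within the scatter: a number 2 percentage points lower from compound 2 to compound 3 (within the scatter). Because that exchange a number 2 percentage points lower from compound 2 to compound 3 (within the scatter) produced no change beyond the scatter, compound 4 is expected to stay close to compound 3, so a number 3 percentage points lower from compound 3 to compound 4 (within the scatter) is estimated to be no larger than the scatter. For the measured compounds named here, with only one such exchange available as a guide, the estimate for compound 4 in this assay is 95%, expected to fall between 80% and 100%.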

Compound 4, a percentage reported as activity, at one concentration (the size of the read-out at that concentration, not a potency): 87%
Estimate against measurement, compound 4: 8 percentage points above, within the range that was stated.
By their numbers in this assay, from the lowest: compound 1; then compound 4; then compounds 3 and 2 (each within the scatter of the next).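

In this assay, the exchange of ethoxy for dimethylamino gives a step beyond the scatter (a number 11 percentage points lower from compound 3 to compound 4 (beyond the scatter)), and the exchange of bromo for dimethylamino does the same (a number 13 percentage points lower from compound 2 to compound 4 (beyond the scatter)), so this aromatic carbon is not indifferent to which group replaces another, as the earlier exchange of bromo for ethoxy alone might have suggested. Ethoxy and dimethylamino match in heavy-atom, donor and acceptor counts and differ in that nitrogen stands where oxygen stood, so those counts alone do not separate the two compounds, and nothing measured here explains the difference. Dimethylamino still leaves the number above that of the unsubstituted compound (a number 12 percentage points higher from compound 1 to compound 4 (beyond the scatter)), so all three groups shown raise the number relative to hydrogen, though dimethylamino sets compound 4 apart from compound 2 and compound 3.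

The compounds shown leave open whether the nitrogen itself matters, which a plain amine or a methylamino group on the same carbon could begin to test. They also leave open how a carboxylic acid or a longer alkoxy chain at this place would read, and each value here describes a single concentration, not a potency.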